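Chain extension on the ester of an anilinoquinazoline cytotoxicity series

The compounds below may be only part of what the source reports. "The series", "measured", "known", "first", "only" and "open" are said of these compounds alone.

Measured compounds:
compound 1, `CCCCCOC(=O)CCC(=O)N1CCN(CCCOc2cc3c(Nc4ccc(F)c(Cl)c4)ncnc3cc2OC)CC1`, 87.1%
compound 2, `CCCCCCCCCCOC(=O)CCC(=O)N1CCN(CCCOc2cc3c(Nc4ccc(F)c(Cl)c4)ncnc3cc2OC)CC1`, 95.7%

The two compounds share one core and differ only in the ester chain. In a functional assay on A549 cells (Homo sapiens) for cytotoxicity, read by MTT assay, with a stated time of 24 h, tested at 10 uM (on this read-out higher numbers stand for a weaker effect at the one concentration tested and lower numbers for a stronger effect), compound 1 gives 87.1%, and compound 2 gives 95.7%. Within the data shown here, compound 2 carries the top number of the two, but the only measured step is a number 8.6 percentage points higher from compound 1 to compound 2 (within the scatter), so the two cannot be told apart.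

Compound 3, `CCCCCCCCCCCCCCOC(=O)CCC(=O)N1CCN(CCCOc2cc3c(Nc4ccc(F)c(Cl)c4)ncnc3cc2OC)CC1`, has not yet been measured. It differs from compound 2 by butyl in place of hydrogen on a saturated chain carbon, ten or more bonds along the chain from an oxygen next to a carbonyl group. Among the measured compounds shown here, the one step that bears on this change is the earlier lengthening of the same chain, a number 8.6 percentage points higher from compound 1 to compound 2 (within the scatter), which stayed within the scatter. A further lengthening is therefore expected to give no step beyond the scatter in this assay.

For compound 3 the estimate in this assay is 95%, with a range from 85% to 102%, which is expected to mean a step of a number 0.7 percentage points lower from compound 2 to compound 3 (within the scatter).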

Compound 3, a percentage reported as activity, at one concentration (the size of the read-out at that concentration, not a potency): 100%
Beside the measured number, compound 3's estimate is 5 percentage points below it; measured number inside the range.
By their numbers in this assay, from the lowest: compounds 1, 2 and 3 (each within the scatter of the next, the first and the last beyond it).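

In this assay, butyl in place of hydrogen on a saturated chain carbon shows a number 4.3 percentage points higher from compound 2 to compound 3 (within the scatter) and so does not separate these two compounds. Across the whole series, nonyl in place of hydrogen on the chain shows a number 12.9 percentage points higher from compound 1 to compound 3 (beyond the scatter) and gives the first step that clears the scatter, a modest weakening of the effect at the one concentration tested. Nothing measured here explains this step.

On these data alone, whether a shorter chain, a free carboxylic acid in place of the ester, or an amine at the end of the chain would bring a stronger effect remains open. The three compounds show only how the effect at one concentration changes across these three chain lengths on the shared core.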